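A Methyl Group Moved on a Sulfonamide

The compounds below may be only part of what the source reports. "The series", "measured", "known", "first", "only" and "open" are said of these compounds alone.

Compound 1, `O=S(=O)(Nc1ccc(-c2nc3ccccc3o2)cc1)c1ccc(Cl)c(C(F)(F)F)c1`, gives only a limit in an assay on isolated protein for inhibition of malate dehydrogenase, mitochondrial (Sus scrofa), with stated times of 45 min and 30 min; on this read-out higher numbers stand for weaker inhibition and lower numbers for stronger inhibition: > 63000 nM.
Compound 2, `Cc1ccc(S(=O)(=O)Nc2ccc3oc(-c4ccccc4)nc3c2)cc1`, gives only a limit in this assay: > 63000 nM.

Among the measured compounds shown here, compound 2 therefore stands at the edge of what this assay can report, with no number behind it, and the one other value shown is also a limit, namely (the limit of > 63000 nM in this assay, at which 2 of the 2 values shown sit). For the measured compounds named here, neither compound shows measurable inhibition, so no step between measured compounds can be sized.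

Compound 3, `Cc1ccccc1S(=O)(=O)Nc1ccc2oc(-c3ccccc3)nc2c1`, differs from compound 2 by 2-methylphenyl in place of 4-methylphenyl on a sulfonyl sulfur. Nothing in the two measured compounds suggests that moving the methyl group on that ring should bring the inhibition into the measurable window; the expected step from compound 2 to compound 3 is a step that the limit leaves unreadable from compound 2 to compound 3, that is, none beyond the scatter. For compound 3 in this assay the estimate is 100000 nM, with a range from 50000 nM to 300000 nM, and most likely it too will be reported only as a limit.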

Compound 3, half-maximal inhibitory concentration: > 63000 nM
Compound 3: no number, only a limit (the forecaster's own chance of this, stated with the estimate: 85%); the middle value does not contradict the limit.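

In this assay compound 3 gives > 63000 nM as a limit and not a number, so no size can be read for the step from compound 2 to compound 3. The compounds shown leave open whether any such sulfonamide inhibits this enzyme measurably at all.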